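Substituting a fluorobenzyl for an isopropylbenzyl group

The source may report more compounds than this note shows. Statements on the series, on what has been measured and on what is new or still open speak of the compounds shown alone.

Compound 1, `C#CCN(CCCOc1ccc2ccc(=O)oc2c1)Cc1ccccc1`: 38600 nM
Compound 2, `C#CCN(CCCOc1ccc2ccc(=O)oc2c1)Cc1ccc(C)cc1`: 116000 nM
Compound 3, `C#CCN(CCCCOc1ccc2ccc(=O)oc2c1)Cc1ccc(C(C)C)cc1`: 35400 nM

These three compounds were all tested in an ADME assay on isolated protein for inhibition of Amine oxidase [flavin-containing] A (Homo sapiens), read by fluorescence and Amplex Red, with stated times of 15 min and 20 min; a higher number here means a weaker inhibitor, a lower number a stronger inhibitor. Compound 3 has the lowest number of the three, but it stands within the scatter of compound 1, so the two cannot be ordered; only compound 2 sits clearly beyond it. Going by the values given here, the one step between compounds that differ in a single place is a 3.0-fold higher number from compound 1 to compound 2 (0.48 log units; beyond the scatter). Compound 4, `C#CCN(CCCCOc1ccc2ccc(=O)oc2c1)Cc1cccc(F)c1`, is not yet measured and differs from compound 3 as follows: 3-fluorophenyl in place of 4-isopropylphenyl on a saturated chain carbon bound to an amine nitrogen. Among the compounds with values here, the single measured step concerns a different group at a different place, so it gives no direct guide, and the change from compound 3 to compound 4 is expected to stay within the scatter, a 1.2-fold lower number from compound 3 to compound 4 (0.07 log units; within the scatter). Compound 4 is therefore estimated at 30000 nM, in the range 10000 nM to 90000 nM.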

Compound 4, half-maximal inhibitory concentration: 69200 nM
The estimate for compound 4 lay 2.3-fold (0.36 log units) below the measured number; the measured number falls inside the stated range.
By their numbers in this assay, from the lowest: compounds 3, 1, 4 and 2 (each within the scatter of the next, the first and the last beyond it).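

At this position, on a saturated chain carbon bound to an amine nitrogen, 3-fluorophenyl in place of 4-isopropylphenyl gives a 2.0-fold higher number from compound 3 to compound 4 (0.29 log units; within the scatter) in this assay. The isopropyl group can therefore give way to a fluorine at a different ring position with no difference that can be told from the usual scatter. No supporting evidence bears on this result. Still open, as far as these compounds go, is how a 4-fluorobenzyl or 3-chlorobenzyl group would read on this same chain, which would separate the identity of the group from its place on the ring.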